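Swapping the Ether Fluoroalkyl on Compound 3

The compounds below may be only part of what the source reports. "The series", "measured", "known", "first", "only" and "open" are said of these compounds alone.

Of the compounds shown here, three have been measured in a functional assay on CHO cells for antagonist activity at sphingosine 1-phosphate receptor 2 (Homo sapiens), read by calcium flux; a lower number here means a stronger inhibitor, a higher number a weaker inhibitor. Among the measured compounds shown here, compound 1 `CCn1nc(CC(=O)Nc2ccc(OC(F)(F)F)c(Cl)c2)c2ccccc2c1=O` gives 199 nM, and compound 2 `O=C(Cc1nn(CC(=O)N2CCOCC2)c(=O)c2ccccc12)Nc1ccc(OC(F)(F)F)c(Cl)c1` gives 30 nM; the step of a 6.6-fold lower number from compound 1 to compound 2 (0.82 log units; beyond the scatter) is the only single-point change with both ends measured. Compound 3 `O=C(O)Cn1nc(Cc2nc3cc(Cl)c(OCC(F)F)cc3[nH]2)c2ccccc2c1=O` gives 12 nM, the lowest number of the three and beyond the scatter from both others. Compound 4 `O=C(O)Cn1nc(Cc2nc3cc(Cl)c(OC(F)(F)F)cc3[nH]2)c2ccccc2c1=O` differs from compound 3 by trifluoromethyl in place of 2,2-difluoroethyl on an oxygen on an aromatic ring. For the measured compounds named here, no measured step covers this exchange: the step from compound 1 to compound 2 alters a different part of the molecule, and although those two carry trifluoromethoxy, they sit on another core. The estimate for compound 4 in this assay is thus a change of no change at the digits printed from compound 3 to compound 4 (within the scatter), within the scatter. Compound 4 is expected to give 12 nM, with a range from 5 nM to 30 nM.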

Compound 4, half-maximal inhibitory concentration: 31 nM
Estimate against measurement, compound 4: 2.6-fold (0.41 log units) below; the whole stated range lies below it.
By their numbers in this assay, from the lowest: compound 3; then compounds 2 and 4 (each within the scatter of the next); then compound 1.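

In this assay, the exchange on the oxygen gives a 2.6-fold higher number from compound 3 to compound 4 (0.41 log units; beyond the scatter), so this position responds to which fluoroalkyl it carries, though the step is modest. Among the compounds shown here, this is the only measured step at this ether, since the earlier step changed a different part of the molecule. No measurement shown here explains the difference between 2,2-difluoroethoxy and trifluoromethoxy. Going by these compounds, what a 2,2,2-trifluoroethyl or a plain ethyl would give on this oxygen remains open. So does whether the same exchange would read alike on the core of compound 1.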